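The source may report more compounds than this note shows. Statements on the series, on what has been measured and on what is new or still open speak of the compounds shown alone.

In a functional assay on LoVo cells (Homo sapiens) for inhibition, read by colorimetric assay and MTT assay, with a stated time of 72 h (on this read-out lower numbers stand for stronger inhibition and higher numbers for weaker inhibition), compound 1 `Cn1c2cnc1OCCCCCCCCOc1ccc(F)cc1-2` gives 43000 nM, compound 2 `C=CCCCCOc1ccccc1-c1cnc(OCCC=C)n1C` gives 12000 nM, and compound 3 `C=CCCCCOc1ccc(C)cc1-c1cnc(OCCC=C)n1C` gives 41000 nM. Compound 3 thus lies within the scatter of compound 1 and well above compound 2. Compound 4 `C=CCCCCOc1ccc(F)cc1-c1cnc(OCCC=C)n1C` is still unmeasured. The change is fluoro in place of methyl on an aromatic carbon. Within the data shown here, one measured step bears on it, a modest one at the same carbon: a 3.4-fold higher number from compound 2 to compound 3 (0.53 log units; beyond the scatter). Removing the methyl might therefore give back part of that loss, so a modest move towards the 12000 nM of compound 2 is expected. The expected change is a 2.1-fold lower number from compound 3 to compound 4 (0.31 log units; beyond the scatter). Compound 4 is estimated at 20000 nM, with an expected range of 8000 nM to 45000 nM.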

Compound 4, half-maximal inhibitory concentration: 38000 nM
Compound 4: the middle estimate sits 1.9-fold (0.28 log units) below what was measured; low and high end bracket the measured number.
By their numbers in this assay, from the lowest: compound 2; then compounds 4, 3 and 1 (each within the scatter of the next).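

In this assay, fluoro and methyl on this carbon, para to the (hex-5-en-1-yl)oxy group, cannot be told apart, with a 1.1-fold lower number from compound 3 to compound 4 (0.03 log units; within the scatter) and thus no return towards compound 2. Fluoro in place of hydrogen brings a 3.2-fold higher number from compound 2 to compound 4 (0.50 log units; beyond the scatter) and so resembles the loss seen with methyl: that loss is not peculiar to methyl, and among compounds 2, 3 and 4 only hydrogen here gives the lower number. No measurement shown explains this.

On these data alone, whether an amine or a methoxy group on this carbon would behave like fluoro and methyl or like hydrogen remains open.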